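Swapping the Azole Headgroup on a Weak Antiproliferative Lactam

The compounds below may be only part of what the source reports. "The series", "measured", "known", "first", "only" and "open" are said of these compounds alone.

For the measured compounds named here, compound 1 `NC(=O)c1ncn(CCC2(O)NC(=O)C(OCc3ccccc3)=C2OCc2ccccc2)n1` is the only compound here with a measured number: in a functional assay on MCF7 cells (Homo sapiens) for antiproliferative activity, read by MTT assay, with a stated time of 72 h (a higher number here means a weaker inhibitor, a lower number a stronger inhibitor), compound 1 gives 61000 nM. Compound 2 `COC(=O)c1ncn(C[C@H](O)[C@H]2OC(=O)C(OCc3ccccc3)=C2OCc2ccccc2)n1` reaches only a limit of this assay, > 100000 nM. That limit is the one noted as the limit of > 100000 nM in this assay, at which 1 of the 2 values shown sits. Compound 3 `NC(=O)c1ncn(CCC2(O)NC(=O)C(OCc3ccccc3)=C2OCc2ccccc2)c1C(N)=O` differs from compound 1 in one place: 4,5-dicarbamoyl-1H-imidazol-1-yl in place of 3-carbamoyl-1H-1,2,4-triazol-1-yl on a saturated chain carbon, two bonds along the chain from a saturated ring carbon. Going by the values given here, no measured step of this kind is available, and the change is expected to move the value little, so the step of a 1.1-fold higher number from compound 1 to compound 3 (0.06 log units; within the scatter) is expected to stay within the usual scatter. Compound 3 is estimated at 70000 nM, with a range from 25000 nM to 200000 nM.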

Compound 3, half-maximal inhibitory concentration: > 100000 nM
Compound 3 was reported as a limit (the forecaster's own chance of this, stated with the estimate: 35%); at least 1.4-fold (0.15 log units) between middle value and limit.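

Compound 3, carrying 4,5-dicarbamoyl-1H-imidazol-1-yl on the saturated chain carbon, gives only a limit in this assay, > 100000 nM, and not a number. The swap reads as an at least 1.6-fold higher number from compound 1 to compound 3 (0.21 log units; that floor lies within the scatter), so it shows no stronger inhibition at this place, and how much weaker it may be cannot be told. The limit now covers most of the set: the limit of > 100000 nM in this assay, at which 2 of the 3 values shown sit.

Going by these compounds, whether an amine or a carboxylic acid in place of the azole headgroup, or a longer chain, would give a clearly lower number stays open. For the compounds shown here, with compound 1 the only measured number, no trend can yet be drawn.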